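A sulfonyl swap at the limit of tolerance

A few compounds are considered here, and "the series" means these few. Any claim that something is new, unique, unknown or untested is made for them only; others in the source may bear on it.

Compound 1 `COc1ccc([C@H]2CC(=O)N(c3cccc(NC(=O)C(C)=O)c3)C2)cc1OC1CCCC1`: > 10000 nM, a limit
Compound 2 `COc1ccc([C@H]2CC(=O)N(c3cccc(NS(=O)(=O)c4cccc(C)c4)c3)C2)cc1OC1CCCC1`: > 10000 nM, a limit

In a functional assay on HEK293 cells (Homo sapiens) for cytotoxicity (a lower number here means that less compound is tolerated, a higher number that more compound is tolerated), compound 2 gives only a limit, > 10000 nM, and no number. It sits at the limit of > 10000 nM in this assay, at which 2 of the 2 values shown sit. For the measured compounds named here, the one measured step is a step that the two limits leave unreadable from compound 1 to compound 2, so it offers no size to carry forward. Compound 3 `COc1ccc([C@H]2CC(=O)N(c3cccc(NS(=O)(=O)c4cc(Br)c(Cl)s4)c3)C2)cc1OC1CCCC1` has 4-bromo-5-chlorothiophen-2-yl in place of 3-methylphenyl on a sulfonyl sulfur. No step beyond the scatter is expected, and no direction can be foreseen, so the estimate reads a step that the limit leaves unreadable from compound 2 to compound 3. In this assay the expected value for compound 3 is 15000 nM, within an estimated range of 5000 nM to 40000 nM.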

Compound 3, half-maximal cytotoxic concentration: > 10000 nM
Compound 3: a limit, no number (the forecaster's own chance of this, stated with the estimate: 75%); the middle value does not contradict the limit.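

In this assay compound 3 gives only a limit, > 10000 nM, so the steps linking compound 1, compound 2 and compound 3 cannot be read. The compounds shown leave open at what concentration each becomes cytotoxic, and whether they differ at all.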